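This account rests on a few compounds, and the source may have more. Where it says the series, first, only, none or still open, it means among the compounds named here.

Measured compounds:
compound 1 `CNC(=O)c1cc(C(=O)N[C@H]2CC[C@H](O)CC2)c([C@@H](C)c2cccc(OC)c2)o1`: 44 nm/s
compound 2 `CCNC(=O)c1cc(C(=O)NC)nn1[C@@H](C)c1ccccc1`: 435 nm/s
compound 3 `CNC(=O)c1cc(C(=O)N[C@H]2CC[C@H](O)CC2)c([C@@H](C)c2cccc(Cl)c2)o1`: 150 nm/s

In an ADME assay for permeability (on this read-out higher numbers stand for higher permeability and lower numbers for lower permeability), compound 2 stands highest of the three, its nearest neighbour being compound 3 and the furthest compound 1. For the measured compounds named here, the single measured step, a 3.4-fold higher number from compound 1 to compound 3 (0.53 log units; beyond the scatter), concerns a different change in a different pair and offers no direct guide here.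

Compound 4 `CNC(=O)c1cc(C(=O)NC)n([C@@H](C)c2ccccc2)n1` differs from compound 2 by hydrogen in place of methyl on a saturated chain carbon bound to an amide-type nitrogen. Going by the values given here, no measured step bears on this change, so a step within the usual scatter of this assay is expected. On that basis compound 4 is expected to give 340 nm/s, with a range from 170 nm/s to 680 nm/s. The expected step is therefore a 1.3-fold lower number from compound 2 to compound 4 (0.11 log units; within the scatter), not beyond the scatter.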

Compound 4, apparent permeability: 280 nm/s
The estimate for compound 4 lay 1.2-fold (0.08 log units) above the measured number; the range from low to high includes it.
By their numbers in this assay, from the lowest: compound 1; then compounds 3, 4 and 2 (each within the scatter of the next, the first and the last beyond it).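

In this assay, ethylcarbamoyl and methylcarbamoyl are not separated at this place on the shared core: the change gives a 1.6-fold lower number from compound 2 to compound 4 (0.19 log units; within the scatter). For the compounds shown here, this is the first step read at a saturated chain carbon bound to an amide-type nitrogen, whereas the earlier step, a 3.4-fold higher number from compound 1 to compound 3 (0.53 log units; beyond the scatter), concerned a different change at a different place. No available evidence accounts for the result.

As far as these compounds go, it remains open whether a longer chain, such as propyl, or a chain ending in an amine would give a step beyond the scatter here. From the compounds shown here alone, the same change on the core of compound 1 also remains open.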